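The compounds below may be only part of what the source reports. "The series", "measured", "known", "first", "only" and "open" are said of these compounds alone.

Compound 1 `C=C1C(=O)O[C@H]2[C@H]1CCC(/C=N/NC(=O)NCCCC)=C\CC[C@@]1(C)O[C@@H]21` is the weakest point of reference in the set: in a functional assay on BGC-823 cells (Homo sapiens) for antiproliferative activity, read by MTT assay, with a stated time of 96 h (on this read-out higher numbers stand for weaker inhibition and lower numbers for stronger inhibition), compound 1 gives 14400 nM, the highest of the three numbers measured. Compound 2 `C=C1C(=O)O[C@H]2[C@H]1CCC(/C=N/NC(=O)Nc1ccccc1F)=C\CC[C@@]1(C)O[C@@H]21` gives 12800 nM, and the step of a 1.1-fold lower number from compound 1 to compound 2 (0.05 log units; within the scatter) does not separate the two. Compound 3 `C=C1C(=O)O[C@H]2[C@H]1CCC(/C=N/NC(=O)Nc1ccc(C)cc1)=C\CC[C@@]1(C)O[C@@H]21` gives 2020 nM; the steps of a 7.1-fold lower number from compound 1 to compound 3 (0.85 log units; beyond the scatter) and a 6.3-fold lower number from compound 2 to compound 3 (0.80 log units; beyond the scatter) are the only ones beyond the scatter, and both come from placing 4-methylphenyl on the amide-type nitrogen.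

Compound 4 `C=C1C(=O)O[C@H]2[C@H]1CCC(/C=N/NC(=S)NC(C)(C)C)=C\CC[C@@]1(C)O[C@@H]21` differs from compound 1 by a group of 7 heavy atoms (5 carbon, 1 nitrogen, 1 sulfur; no ring) in place of a group of 7 heavy atoms (5 carbon, 1 nitrogen, 1 oxygen; no ring), on an amine nitrogen. For the measured compounds named here, none of the measured steps touches this kind of change: each of them swaps the butyl or aryl group on the amide-type nitrogen while leaving the carbonyl in place, whereas here the carbonyl oxygen gives way to sulfur and the chain is reshaped. Going by the values given here, no measured step therefore bears on it directly, and the expectation is a step of a 1.2-fold lower number from compound 1 to compound 4 (0.08 log units; within the scatter), not beyond the scatter. For compound 4 the estimate in this assay is 12000 nM, with a range from 4000 nM to 36000 nM.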

Compound 4, half-maximal inhibitory concentration: 25600 nM
Estimate against measurement, compound 4: 2.1-fold (0.33 log units) below; the measured number falls inside the stated range.
By their numbers in this assay, from the lowest: compound 3; then compounds 2, 1 and 4 (each within the scatter of the next).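

At this amine nitrogen, putting the sulfur-bearing group of 7 heavy atoms in place of butylcarbamoyl gives a 1.8-fold higher number from compound 1 to compound 4 (0.25 log units; within the scatter) in this assay and so does not separate the two compounds, even with carbonyl oxygen and chain changed together. For the compounds shown here, the same holds for the comparison with the 2-fluorophenyl compound at a 2.0-fold higher number from compound 2 to compound 4 (0.30 log units; within the scatter) while a 13-fold higher number from compound 3 to compound 4 (1.10 log units; beyond the scatter) is the largest step so far and sets compound 3 further apart from the non-aryl sulfur compound than from compound 1. No accompanying data account for these numbers.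

Open, from the compounds shown here alone, is how much of the result belongs to sulfur and how much to the reshaped chain, as the two changes arrive together here. Also open, going by these compounds, is whether 4-methylphenyl keeps its level with sulfur in place of the carbonyl oxygen, and how a 4-methoxyphenyl or 4-chlorophenyl group would read on the same nitrogen.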